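The source may hold more compounds than are shown below. What is called first, only, known or untested is meant among the compounds shown, and "the series" means these compounds.

Compound 1, `COCc1ccccc1C1CCc2nc[nH]c2C1`: in a functional assay on CHO cells for agonist activity at Alpha-1D adrenergic receptor (Homo sapiens), read by FLIPR and calcium flux (a lower number here means that less compound is needed, a higher number that more compound is needed for the effect), compound 1 gives > 10000 nM; > 10000 nM (2 entries), a limit of the assay and not a number.
Compound 2, `COCc1ccccc1C1Cc2nccn2C1`: in this assay compound 2 gives > 10000 nM, again a limit of the assay and not a number.

Compound 2 therefore stands only at the limit of > 10000 nM in this assay, at which 1 of the 2 values shown sits, and no single number is known for it. The change considered here is fluoro in place of methoxymethyl on an aromatic carbon, giving compound 3, `Fc1ccccc1C1Cc2nccn2C1`. Going by the values given here, no step between two measured compounds is available to set the size of this change against, so the expectation rests on the two limits alone. The step of a number no higher from compound 2 to compound 3 (the limit leaves the size open) is expected to be small, within the usual scatter, and a limit is again the most likely outcome. Compound 3 is thus estimated at 10000 nM in this assay, with a range from 1500 nM to 40000 nM.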

Compound 3, half-maximal effective concentration: 301 nM
Estimate against measurement, compound 3: 33-fold (1.52 log units) above, and the stated range ends above it.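

Going by these compounds alone, compound 3 gives 301 nM in this assay and so is the first compound here with a measured number rather than a limit of the assay. Fluoro in place of methoxymethyl on this aromatic carbon brings an at least 33-fold lower number from compound 2 to compound 3 (1.52 log units; beyond the scatter) and shows that one small change at this single place can decide whether a number can be read at all. Going by these compounds, the full size of the step stays unknown because compound 2 has only a limit of the assay: the limit of > 10000 nM in this assay, at which 1 of the 3 values shown sits.

On these data alone, it remains open whether the gain comes from losing methoxymethyl or from gaining fluoro, and a plain hydrogen or a chloro group on this carbon would help to separate the two. Also open, as far as these compounds go, is whether fluoro would do the same on the core of compound 1.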